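From fluoro to trifluoromethyl on the shared core

This account rests on a few compounds, and the source may have more. Where it says the series, first, only, none or still open, it means among the compounds named here.

compound 1 `O=S(=O)(CS(=O)(=O)C(F)(F)F)c1ccc(F)cc1` gives 3150000 nM
compound 2 `O=S(=O)(CS(=O)(=O)C(F)(F)F)c1ccc(Cl)cc1` gives 4000000 nM
compound 3 `O=S(=O)(CS(=O)(=O)C(F)(F)F)c1ccc(Cl)c(Cl)c1` gives 5400000 nM
compound 4 `O=S(=O)(CS(=O)(=O)C(F)(F)F)c1ccc(C(F)(F)F)cc1` is not yet measured

All of these numbers come from a functional assay (mitochondria, liver) with Rattus norvegicus as the target (a lower number here means a stronger inhibitor, a higher number a weaker inhibitor), and they sit close together. Compound 1 stands level with both other measured compounds once the usual scatter is taken into account. The step now in view leads to compound 4 and is counted as trifluoromethyl in place of fluoro on an aromatic carbon in a single change: trifluoromethyl in place of fluoro on an aromatic carbon, para to a large group.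

Within the data shown here, two measured steps bear on it. The closer one is a 1.3-fold higher number from compound 1 to compound 2 (0.10 log units; within the scatter) in which chloro takes the place of fluoro on an aromatic carbon. The other is a 1.4-fold higher number from compound 2 to compound 3 (0.13 log units; within the scatter) in which chloro takes the place of hydrogen on an aromatic carbon. Neither of them leaves the scatter. Among the measured compounds shown here, no measured compound carries trifluoromethyl, so this group remains untested here and the expectation rests on these two small steps alone. No shift beyond the scatter is expected in either direction, and the estimated step is a 1.4-fold higher number from compound 1 to compound 4 (0.15 log units; within the scatter) for this change. For compound 4 the expected value is 4500000 nM with an estimated range of 2500000 nM to 8000000 nM in this measurement.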

Compound 4, half-maximal inhibitory concentration: 5400000 nM
Beside the measured number, compound 4's estimate is 1.2-fold (0.08 log units) below it; low and high end bracket the measured number.
By their numbers in this assay, from the lowest: compounds 1, 2, 3 and 4 (each within the scatter of the next).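

In this assay, trifluoromethyl brings four heavy atoms to the aromatic carbon para to a large group, where fluoro brings one, yet the change stays within the scatter, with a 1.7-fold higher number from compound 1 to compound 4 (0.23 log units; within the scatter). Replacing chloro at the same carbon gives the same reading, with a 1.4-fold higher number from compound 2 to compound 4 (0.13 log units; within the scatter). Across compound 1, compound 2 and compound 4, then, this position tolerates the move from a single halogen to the larger trifluoromethyl group without any step leaving the scatter, and none of these three compounds goes against that reading; nothing in the material shown accounts for this flat result.

Going by these compounds, whether any group at this position can move the number beyond the scatter remains open, since an amine, a carboxylic acid or a longer alkyl chain in place of trifluoromethyl would put that to a test that these halogen-bearing compounds cannot. The compounds shown also leave open how the number would respond to a change elsewhere in the shared core, such as an amine or a methyl group on its central carbon.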